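This account rests on a few compounds, and the source may have more. Where it says the series, first, only, none or still open, it means among the compounds named here.

In a functional assay on PC-12 cells (Rattus norvegicus) for cytotoxicity, read by MTT assay, with stated times of 2 h and 24 h, tested at 1 uM (a lower number here means a weaker effect, a higher number a stronger effect of the compound at the concentration tested), compound 1 `Oc1cc(C(F)(F)F)ccc1-c1nc(-c2ccccc2O)n(-c2ccc(Br)cc2)n1` gives 69.4% and compound 2 `Oc1cc(C(F)(F)F)ccc1-c1nc(-c2ccccc2O)n(-c2cccc(C(F)(F)F)c2)n1` gives 71.5%. Of the two numbers, compound 2 sits at the end reached by a number 2.1 percentage points higher from compound 1 to compound 2 (within the scatter), a difference within the scatter, so the two compounds are not separable here. Compound 3 `Cc1cc(C)cc(-n2nc(-c3ccc(C(F)(F)F)cc3O)nc2-c2ccccc2O)c1` differs from compound 2 by 3,5-dimethylphenyl in place of 3-(trifluoromethyl)phenyl on an aromatic nitrogen. Within the data shown here, the only measured step also exchanges the group on the aromatic nitrogen and stayed within the scatter, so no step beyond the scatter is expected in this assay. Compound 3 is estimated at 70% with a range of 55% to 85%. The expected step is a number 1.5 percentage points lower from compound 2 to compound 3 (within the scatter), within the scatter.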

Compound 3, a percentage reported as activity, at one concentration (the size of the read-out at that concentration, not a potency): 76.9%
Compound 3: middle estimate off by 6.9 percentage points, on the low side; measured number inside the range.
By their numbers in this assay, from the lowest: compounds 1, 2 and 3 (each within the scatter of the next).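

With 3,5-dimethylphenyl, whose added atoms are carbon only, on the aromatic nitrogen, this assay gives a number 5.4 percentage points higher from compound 2 to compound 3 (within the scatter) and a number 7.5 percentage points higher from compound 1 to compound 3 (within the scatter). Substituted phenyl groups with bromine, fluorine or only carbon in their substituents therefore leave compound 1, compound 2 and compound 3 unseparated at this position. No available measurement explains the read-out at this position.

From the compounds shown here alone, all three groups here are substituted phenyl rings, so a carboxylic acid, an amine or a longer alkyl chain on this nitrogen remains open. Going by these compounds, it also remains open whether either 2-hydroxyphenyl-type group on the shared core moves the read-out beyond the scatter.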